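Hydroxy to methoxy on compound 1

The compounds below may be only part of what the source reports. "The series", "measured", "known", "first", "only" and "open" are said of these compounds alone.

Among the measured compounds shown here, in a functional assay on U-251 cells (Homo sapiens) for antiproliferative activity, read by sulforhodamine B assay, with a stated time of 48 h (on this read-out higher numbers stand for weaker inhibition of growth and lower numbers for stronger inhibition of growth), compound 1 (`O=C(NCCCNc1cc(-c2cn(-c3ccccc3)nc2-c2cccc(O)c2)ccn1)Nc1ccc(F)cc1`) gives 7550 nM and compound 2 (`O=C(NCCCNc1cc(-c2cn(-c3ccccc3)nc2-c2cccc(O)c2)ccn1)Nc1cccc(C(F)(F)F)c1`) gives 7450 nM as the only other measured number, so the two stand level within the usual scatter. Compound 3 (`COc1cccc(-c2nn(-c3ccccc3)cc2-c2ccnc(NCCCNC(=O)Nc3ccc(F)cc3)c2)c1`) keeps the core of compound 1 and alters a single group: methyl in place of hydrogen on an oxygen on an aromatic ring turns 3-hydroxyphenyl into 3-methoxyphenyl. For the measured compounds named here, the one measured step is a 1.0-fold lower number from compound 1 to compound 2 (0.01 log units; within the scatter) for 3-(trifluoromethyl)phenyl in place of 4-fluorophenyl on an amide-type nitrogen. Going by the values given here, that step concerns a different place, and no measured step touches the hydroxy group, so the guidance is thin. No step beyond the scatter is therefore expected in this assay for this change, though the uncertainty is wide. The estimate amounts to a 1.1-fold higher number from compound 1 to compound 3 (0.03 log units; within the scatter) as an expected step. Compound 3 is estimated at 8000 nM with an expected range of 3500 nM to 18000 nM on repeated measurement.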

Compound 3, concentration for total growth inhibition: > 37000 nM
Compound 3: only a limit was reported; the forecaster's own chance of this, stated with the estimate: 10%; middle value at least 4.6-fold (0.66 log units) from the limit.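

In this assay, methoxy in place of hydroxy on the 3-hydroxyphenyl group brings an at least 4.9-fold higher number from compound 1 to compound 3 (0.69 log units; beyond the scatter), so growth inhibition here responds to the addition of a single methyl on that oxygen. Among the compounds shown here, the only earlier step, at a different place, was a 1.0-fold lower number from compound 1 to compound 2 (0.01 log units; within the scatter), and so it gave no sign of a change of this size. Compound 3 is reported only as a limit, and the full size of the step stays unknown: the limit of > 37000 nM in this assay, at which 1 of the 3 values shown sits.

The compounds shown leave open whether the loss of the hydroxy hydrogen or the presence of the methyl matters, and an amine in place of the hydroxy group, or an ethoxy group in place of the methoxy, would help to separate the two. On these data alone, whether the same change acts alike on compound 2, with its 3-(trifluoromethyl)phenyl group, also remains open.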